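A few compounds are considered here, and "the series" means these few. Any claim that something is new, unique, unknown or untested is made for them only; others in the source may bear on it.

Compound 1, `O=C(Nc1cccc(/C=C/C(=O)c2nc3ccccc3[nH]2)c1)c1cccc(Br)c1`, gives 5210 nM in a functional assay on MCF7 cells (Homo sapiens) for antiproliferative activity, read by MTT assay, with a stated time of 48 h; on this read-out lower numbers stand for stronger inhibition and higher numbers for weaker inhibition.
Compound 2, `Cc1ccc(C(=O)Nc2cccc(/C=C/C(=O)c3nc4ccccc4[nH]3)c2)cc1`, gives 9690 nM in this assay.

Only these two compounds have been measured, and the one step between them, a 1.9-fold higher number from compound 1 to compound 2 (0.27 log units; within the scatter), lies within the scatter, so the two values cannot be told apart; compound 2 therefore stands level with compound 1 on the numbers shown.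

Compound 3, `COc1ccc(C(=O)Nc2cccc(/C=C/C(=O)c3nc4ccccc4[nH]3)c2)cc1`, has not yet been measured. It differs from compound 2 in one place: methoxy in place of methyl on an aromatic carbon, which reads, cut one bond further out, as (4-methylphenyl)carbonyl to (4-methoxyphenyl)carbonyl.

Going by the values given here, the only measured step that bears on this change is the one from compound 1 to compound 2, which swapped the substituent on the same aryl ring and moved the number by a 1.9-fold higher number from compound 1 to compound 2 (0.27 log units; within the scatter), within the scatter. Among the compounds with values here, no measured pair tests methoxy against methyl directly. On this basis the step from compound 2 to compound 3 in this assay is expected to be a 1.2-fold lower number from compound 2 to compound 3 (0.08 log units; within the scatter), nothing beyond the scatter. Compound 3 is therefore estimated at 8000 nM, with a range from 3000 nM to 20000 nM.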

Compound 3, half-maximal inhibitory concentration: 20100 nM
Compound 3: the middle estimate sits 2.5-fold (0.40 log units) below what was measured; the whole stated range lies below it.
By their numbers in this assay, from the lowest: compounds 1 and 2 (each within the scatter of the next); then compound 3.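

In this assay, methoxy in place of methyl on an aromatic carbon, para to a large group, gives a 2.1-fold higher number from compound 2 to compound 3 (0.32 log units; beyond the scatter), so the choice of group at this place can move the number beyond the scatter, which the step between compound 1 and compound 2 did not show. The change from 3-bromophenyl to 4-methoxyphenyl gives a 3.9-fold higher number from compound 1 to compound 3 (0.59 log units; beyond the scatter), which makes compound 3 the weakest of the three, although both steps are modest. Nothing available here accounts for the higher number that comes with methoxy.

The compounds shown leave open whether the rise with methoxy is particular to that group or would also appear with a hydroxy, an amine or a longer chain such as ethoxy at the same place. Going by these compounds alone, they also cannot separate the identity of a substituent from its place on the ring, since bromine is seen only in 3-bromophenyl, and a 4-bromophenyl group or a 3-methoxyphenyl group would be needed to pull the two apart.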